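The compounds below may be only part of what the source reports. "The series", "measured", "known", "first", "only" and "open" are said of these compounds alone.

Compound 2, `C=C[C@@](C)(/C=C/c1ccc(O)cc1)CC/C=C(\C)C=O`, was tested in an ADME assay on BJ cells (Homo sapiens) for cytotoxicity, with a stated time of 72 h; on this read-out higher numbers stand for an effect only at larger amounts of compound and lower numbers for an effect already at smaller amounts. In this assay compound 2 gives > 36600 nM, which is a limit of the assay rather than a number. Compound 1, `C=C[C@@](C)(/C=C/c1ccc(O)cc1)CC/C=C/C(=O)OCC`, carries a 2-(ethoxycarbonyl)ethenyl group where compound 2 carries a 2-formylprop-1-en-1-yl group. In this assay compound 1 gives > 36600 nM, likewise a limit. The size of the step that the two limits leave unreadable from compound 1 to compound 2 cannot be read because of the limit of > 36600 nM in this assay, at which 2 of the 2 values shown sit. Compound 3, `C=C[C@@](C)(/C=C/c1ccc(O)cc1)CC/C=C(C)/C=C/C(=O)OCC`, differs from compound 2 by 2-(ethoxycarbonyl)ethenyl in place of formyl on a double-bonded chain carbon bound to a double-bonded chain carbon and a saturated chain carbon. Among the measured compounds shown here, the single measured step bears on this change but gives no readable size, so no step beyond the scatter can be foreseen, and compound 3 is expected to return a limit as well. Compound 3 is therefore estimated at 40000 nM, within 20000 nM to 100000 nM. This estimate means an expected step that the limit leaves unreadable from compound 2 to compound 3.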

Compound 3, half-maximal effective concentration: > 36600 nM
Compound 3: only a limit was reported; the forecaster's own chance of this, stated with the estimate: 80%; the middle value is on the limit's open side.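

No size can be read for the step between compound 2 and compound 3, because both results are limits of the assay rather than numbers: the limit of > 36600 nM in this assay, at which 3 of the 3 values shown sit. The compounds shown leave open whether these changes to the chain alter the result in this assay at all, and at what amount of compound any of them would show an effect.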